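The compounds below may be only part of what the source reports. "The series", "measured", "known", "first", "only" and "open" are said of these compounds alone.

Compound 1 `CN(C)S(=O)(=O)c1ccc(F)c(C#Cc2cc(Cl)ccc2OCC(=O)O)c1`: < 10 mL.min-1.g-1
Compound 2 `COCCNS(=O)(=O)c1ccc(C)c(C#Cc2cc(Cl)ccc2OCC(=O)O)c1`: < 10 mL.min-1.g-1
Compound 3 `Cc1ccc(S(=O)(=O)N2CCOCC2)cc1C#Cc1cc(Cl)ccc1OCC(=O)O`: < 10 mL.min-1.g-1

In an in vitro ADME assay on microsomes from liver (Homo sapiens) for metabolic stability, read by LC-MS, tested at 1 uM (on this read-out higher numbers stand for fast clearance and lower numbers for slow clearance), compound 3 gives no number, only the limit < 10 mL.min-1.g-1. The other two entries are limits as well, and the whole series comes down to the limit of < 10 mL.min-1.g-1 in this assay, at which 3 of the 3 values shown sit. The next compound is compound 4 `Cc1ccc(S(C)(=O)=O)cc1C#Cc1cc(Cl)ccc1OCC(=O)O`, which carries methyl in place of morpholin-4-yl on a sulfonyl sulfur. Going by the values given here, one measured step touches the same sulfonyl sulfur, and it is a step that the two limits leave unreadable from compound 2 to compound 3. It therefore offers no size to carry over to the new change. Compound 3 holds the limit < 10 mL.min-1.g-1, and on that footing alone no step beyond the scatter is expected in this assay. The expected step is a step that the limit leaves unreadable from compound 3 to compound 4. Among the compounds with values here, this expectation is weakly founded, since none of the measured compounds has a readable number. For compound 4 the estimated value is 6 mL.min-1.g-1, with an expected range of 3 mL.min-1.g-1 to 12 mL.min-1.g-1.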

Compound 4, intrinsic clearance in microsomes: 14 mL.min-1.g-1
Beside the measured number, compound 4's estimate is 2.3-fold (0.37 log units) below it, outside the stated range (above it).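

In this assay compound 4 is the only compound shown with a readable number rather than a limit, which gives this sulfonyl sulfur its first point on the scale. Methyl in place of morpholin-4-yl gives an at least 1.4-fold higher number from compound 3 to compound 4 (0.14 log units; that floor lies within the scatter) and methyl in place of (2-methoxyethyl)amino gives an at least 1.4-fold higher number from compound 2 to compound 4 (0.14 log units; that floor lies within the scatter) on the same sulfonyl sulfur. Both steps are only floors, and neither can yet be called a real rise because their starting values are limits and not numbers: the limit of < 10 mL.min-1.g-1 in this assay, at which 3 of the 4 values shown sit.

The steps among the compounds held at the limit cannot be read. From the compounds shown here alone, it also stays open whether an ethyl or a piperidin-1-yl on a sulfonyl sulfur would give a readable number like that of compound 4 or stay at the limit.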